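From Compound 3 to Compound 4: An Estimate Before Measurement

This account rests on a few compounds, and the source may have more. Where it says the series, first, only, none or still open, it means among the compounds named here.

Of the compounds shown here, three built on one shared core have been tested in an assay on isolated protein for inhibition of Rho-associated protein kinase 1 (Homo sapiens), read by scintillation counting, radiometric assay and 33P incorporation, with a stated time of 40 min, in the presence of a further agent that is not named here; a lower number here means a stronger inhibitor, a higher number a weaker inhibitor. Compound 1 `CCc1ccc(C(=O)Nc2cccc(NC(=O)COc3ccc4c(=O)ccoc4c3)c2)cc1` gives 235 nM. Compound 2 `Cc1nc(C(=O)Nc2cccc(NC(=O)COc3ccc4c(=O)ccoc4c3)c2)cs1` gives 473 nM, and compound 3 `O=C(COc1ccc2c(=O)ccoc2c1)Nc1cccc(NC(=O)c2cnc(C(F)(F)F)s2)c1` gives 160 nM. Compound 3 thus holds the lowest number of the three; its gap to compound 1 stays within the usual scatter, while the step of a 3.0-fold lower number from compound 2 to compound 3 (0.47 log units; beyond the scatter) lies beyond it, so compound 3 cannot be called the strongest of the set.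

Compound 4 `Cn1ccc(S(=O)(=O)Nc2cccc(NC(=O)COc3ccc4c(=O)ccoc4c3)c2)n1` has not been measured. It differs from compound 3 in one place: a group of 9 heavy atoms (4 carbon, 2 nitrogen, 2 oxygen, 1 sulfur; one five-membered aromatic ring with 2 hetero atoms) in place of a group of 11 heavy atoms (5 carbon, 1 nitrogen, 1 oxygen, 3 fluorine, 1 sulfur; one five-membered aromatic ring with 2 hetero atoms), on a nitrogen on an aromatic ring. The measured steps that changed the group on this same nitrogen are a 1.5-fold lower number from compound 1 to compound 3 (0.17 log units; within the scatter) and a 3.0-fold lower number from compound 2 to compound 3 (0.47 log units; beyond the scatter), one within the scatter and one modest. The change to compound 4 exchanges more of that group than either of those, so a larger shift is expected, and in the weaker direction. The estimated step is a 3.8-fold higher number from compound 3 to compound 4 (0.57 log units; beyond the scatter). Compound 4 is therefore expected to give about 600 nM in this assay, within a range from 150 nM to 2500 nM.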

Compound 4, half-maximal inhibitory concentration: > 10000 nM
Compound 4: a limit, no number; the forecaster's own chance of this, stated with the estimate: 10%; middle value at least 16-fold (1.22 log units) away from the limit.
By their numbers in this assay, from the lowest: compounds 3, 1 and 2 (each within the scatter of the next, the first and the last beyond it). At a limit, above all of these: compound 4.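

Compound 4 has a limit in this assay, not a number: the limit of > 10000 nM in this assay, at which 1 of the 4 values shown sits.

The three earlier compounds, all joined to this nitrogen through a carbonyl, differed by steps that were within the scatter or modest, whereas the sulfonyl link and ring of compound 4 give an at least 62-fold higher number from compound 3 to compound 4 (1.79 log units; beyond the scatter) and an at least 21-fold higher number from compound 2 to compound 4 (1.32 log units; beyond the scatter) as well as an at least 42-fold higher number from compound 1 to compound 4 (1.62 log units; beyond the scatter) and all three steps are large. Among the compounds shown here, this nitrogen therefore does not accept every group, and the earlier compounds gave no sign of so sharp a drop.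

Compound 4 changes the link and the ring in a single step, so the compounds shown cannot say which of the two accounts for the drop, and the limit hides its true size. Also open, as far as these compounds go, is how this position would read with a simple amine or a urea, or with the ring of compound 4 joined through a carbonyl.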